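From carboxy to methoxycarbonyl: compound 3 to compound 4

A few compounds are considered here, and "the series" means these few. Any claim that something is new, unique, unknown or untested is made for them only; others in the source may bear on it.

In a physicochemical assay for solubility, at pH 7.4 (a higher number here means a more soluble compound, a lower number a less soluble compound), compound 1 (`NS(=O)(=O)c1ccc(S(=O)(=O)CCCO)cc1`) gives 7200 ug/mL, compound 2 (`COC(=O)c1cc(S(N)(=O)=O)ccc1S(=O)(=O)CCO`) gives 33400 ug/mL and compound 3 (`NS(=O)(=O)c1ccc(S(=O)(=O)CCCO)c(C(=O)O)c1`) gives 53000 ug/mL. Compound 2 and compound 3 lie within the scatter of each other, and compound 3 stands clearly clear of compound 1.

The next compound is compound 4 (`COC(=O)c1cc(S(N)(=O)=O)ccc1S(=O)(=O)CCCO`). The change is methyl in place of hydrogen on an oxygen next to a carbonyl group, so carboxy becomes methoxycarbonyl.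

Within the data shown here, one measured step bears on this group: a 7.4-fold higher number from compound 1 to compound 3 (0.87 log units; beyond the scatter), with carboxy in place of hydrogen on an aromatic carbon. Among the measured compounds shown here, it is modest, and no measured step covers the methyl itself. The closest guide already holds methoxycarbonyl on a shorter chain than compound 4. This guide is compound 2, which gives 33400 ug/mL. That value argues against a fall all the way to the level of compound 1, while the step to compound 3 leaves room for some loss.

The expected change is a modest one downward, estimated as a 2.4-fold lower number from compound 3 to compound 4 (0.38 log units; beyond the scatter). For compound 4 the estimated value is 22000 ug/mL, with an expected range from 9000 ug/mL to 50000 ug/mL.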

Compound 4, solubility: 14000 ug/mL
Compound 4: middle estimate off by 1.6-fold (0.20 log units), on the high side; low and high end bracket the measured number.
By their numbers in this assay, from the lowest: compounds 1 and 4 (each within the scatter of the next); then compounds 2 and 3 (each within the scatter of the next).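

In this assay, methyl on the oxygen of the carboxy group takes back most of the rise that carboxy gave the core of compound 1: the ester step reads as a 3.8-fold lower number from compound 3 to compound 4 (0.58 log units; beyond the scatter) and, set against the parent without any group at this aromatic carbon, as a 1.9-fold higher number from compound 1 to compound 4 (0.29 log units; within the scatter) and so stays within the scatter. The chain also counts once methoxycarbonyl is in place, with a 2.4-fold lower number from compound 2 to compound 4 (0.38 log units; beyond the scatter) for hydroxymethyl in place of hydroxy on a saturated chain carbon, two bonds along the chain from a sulfonyl sulfur, though this is a single pair and no trend. Nothing measured here gives a reason for these steps.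

Open, going by these compounds, is how a primary amide or an ethoxycarbonyl group at this aromatic carbon would read against carboxy and methoxycarbonyl. Also open, on these data alone, is whether the chain step would keep its size with carboxy or hydrogen on that carbon, and where a longer chain ending in hydroxy would fall.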